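Swapping the Amide Substituent in a Shared Furan Core Series

This account rests on a few compounds, and the source may have more. Where it says the series, first, only, none or still open, it means among the compounds named here.

Of the compounds shown here, three built on one shared core have been tested in a functional assay on the whole organism for inhibition, with Mus musculus as the target, at a dose of 10 mg/kg by the oral route; a lower number here means less inhibition, a higher number more inhibition at the dose given (going by the name of the read-out). Compound 1 `COc1ccc(-c2ccccc2)c2cc(C(=O)Nc3c(Cl)cncc3Cl)oc12` gives 74% in this assay. Compound 2 `COC(=O)Nc1cc2c(-c3ccccc3)ccc(OC)c2o1` gives 86% in this assay. Compound 3 `COc1ccc(-c2ccccc2)c2cc(C(=O)NN3CCOCC3)oc12` gives 78% in this assay, which places it second highest of the three numbers, yet both of its neighbours lie within the usual scatter of it: compound 1 sits a little lower and compound 2 a little higher, so no order among them can be read from these figures.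

The step considered here leads from compound 3 to compound 4 `COc1ccc(-c2ccccc2)c2cc(C(=O)Nc3ccncc3)oc12`, which has not yet been measured in this assay. The change is pyridin-4-yl in place of morpholin-4-yl on an amide-type nitrogen.

For the measured compounds named here, only one measured step bears on this position: a number 4 percentage points higher from compound 1 to compound 3 (within the scatter). That step exchanged one ring on the amide-type nitrogen for another and produced no change beyond the scatter, and compound 1 already carries a pyridine-type ring at this place. The expectation is therefore a step of a number 2 percentage points lower from compound 3 to compound 4 (within the scatter) in this assay, that is, none beyond the scatter. Compound 4 is estimated to give 76% in this assay, with a range from 60% to 90%.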

Compound 4, a percentage reported as inhibition, in the whole organism at one dose (the size of the read-out at that dose, not a potency): 40%
Compound 4: middle estimate off by 36 percentage points, on the high side; the whole stated range lies above it.
By their numbers in this assay, from the lowest: compound 4; then compounds 1, 3 and 2 (each within the scatter of the next, the first and the last beyond it).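

In this assay, the group on the amide-type nitrogen turns out to matter a great deal: pyridin-4-yl in place of morpholin-4-yl gives a number 38 percentage points lower from compound 3 to compound 4 (beyond the scatter), whereas the only earlier step at this place, a number 4 percentage points higher from compound 1 to compound 3 (within the scatter), had shown nothing beyond the scatter. Having a pyridine-type ring at this place is therefore not enough to keep the number up, since pyridin-4-yl in place of 3,5-dichloropyridin-4-yl gives a number 34 percentage points lower from compound 1 to compound 4 (beyond the scatter), so two groups as different as morpholin-4-yl and 3,5-dichloropyridin-4-yl stay within the scatter of each other while the plain pyridin-4-yl stands apart from both. No measurement at hand offers an explanation for this separation.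

The compounds shown do not tell whether the low number belongs to pyridin-4-yl alone or extends to other aromatic rings on this nitrogen, such as phenyl or pyridin-3-yl. They also leave open whether a saturated ring such as piperidin-1-yl would match morpholin-4-yl, and whether a chloro group on the pyridine ring, or some other halogen such as fluoro, would be enough to restore the number in this assay.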